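The source may report more compounds than this note shows. Statements on the series, on what has been measured and on what is new or still open speak of the compounds shown alone.

Compound 1 `O=C(NS(=O)(=O)c1ccccc1)n1ccc2cccnc21`: in a functional assay on MCF7 cells (Homo sapiens) for antiproliferative activity, read by MTT assay, with a stated time of 24 h, tested at 10 uM (on this read-out higher numbers stand for more inhibition at the one concentration tested (going by the name of the read-out) and lower numbers for less inhibition), compound 1 gives 19%.
Compound 2 `O=C(NS(=O)(=O)c1ccc2ccccc2c1)n1ccc2cccnc21`: in this assay compound 2 gives 1.9%.
Compound 3 `O=C(NS(=O)(=O)c1ccccc1)n1ccc2c(Cl)ccnc21`: in this assay compound 3 gives 3.32%.

Compound 3 stands second highest of these three numbers. Its nearest neighbour is compound 2, whose value lies within the scatter of it, so no order between the two can be claimed; compound 1 lies clearly above it. Among the measured compounds shown here, the one measured step that touches the same aromatic carbon is a number 15.7 percentage points lower from compound 1 to compound 3 (beyond the scatter), chloro in place of hydrogen. Compound 4 `CN(C)c1ccnc2c1ccn2C(=O)NS(=O)(=O)c1ccccc1` carries yet another group at that carbon: dimethylamino in place of chloro on an aromatic carbon. For the measured compounds named here, no measured step shows what dimethylamino does there, so the only guide is that the unsubstituted compound 1 sits well above the chloro compound 3. A small move back upward seems as likely as none at all. Compound 4 is expected to give about 8%, with a range from -5% to 25%. For compound 4 this means an expected step of a number 4.7 percentage points higher from compound 3 to compound 4 (within the scatter), which is within the scatter.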

Compound 4, a percentage reported as inhibition, at one concentration (the size of the read-out at that concentration, not a potency): 26.9%
Beside the measured number, compound 4's estimate is 18.9 percentage points below it; measured number above the stated range.
By their numbers in this assay, from the lowest: compounds 2 and 3 (each within the scatter of the next); then compounds 1 and 4 (each within the scatter of the next).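

In this assay, the group at this carbon, opposite the ring nitrogen, clearly matters: dimethylamino in place of chloro gives a number 23.6 percentage points higher from compound 3 to compound 4 (beyond the scatter). Dimethylamino in place of hydrogen gives a number 7.9 percentage points higher from compound 1 to compound 4 (within the scatter), so this carbon can carry a substituent without the loss seen with chloro, and that loss is not a general result of substituting here. Nothing available explains why these two groups behave so differently.

On these data alone, whether other groups at this carbon would match dimethylamino or chloro remains open, for example a simple amine, a methoxy group or a longer chain such as diethylamino. As far as these compounds go, it is also open whether dimethylamino would have a similar effect on the otherwise different structure of compound 2, and these single-concentration readings do not show potency.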